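Fused diamine core: aryl ether against aryl thioether

A few compounds are considered here, and "the series" means these few. Any claim that something is new, unique, unknown or untested is made for them only; others in the source may bear on it.

Values in a functional assay on KM12 cells (Homo sapiens) for inhibition, read by sulforhodamine B assay, with a stated time of 48 h; a higher number here means a weaker inhibitor of growth, a lower number a stronger inhibitor of growth:

- compound 1 `Nc1cc(N)c2nc(-c3ccccc3)c(Oc3ccc(Cl)c(Cl)c3)nc2c1`: 39800 nM
- compound 2 `Nc1cc(N)c2nc(-c3ccccc3)c(NCc3ccc(Cl)c(Cl)c3)nc2c1`: 21400 nM
- compound 3 `CCOC(=O)[C@H](CCC(=O)O)NC(=O)c1ccc(Sc2nc3cc(N)cc(N)c3nc2-c2ccccc2)cc1`: < 100000 nM

Compound 1 and compound 2 sit within the usual scatter of each other in this assay, so the two numbers cannot be ranked. Compound 3 gives only a limit in this assay, namely (the limit of < 100000 nM in this assay, at which 1 of the 3 values shown sits), and no number. All three share the same core; they differ only in the group on the aromatic carbon that carries the aryl ether, the benzylamine or the thioether. Compound 4 `Nc1cc(N)c2nc(-c3ccccc3)c(Sc3ccc(F)cc3)nc2c1` has not yet been measured. Relative to compound 1 it shows ((4-fluorophenyl)sulfanyl in place of 3,4-dichlorophenoxy on an aromatic carbon). No measured pair separates a single change of this kind, so the expectation rests on the spread of the numbers shown. The change from compound 1 is expected to amount to a 1.3-fold lower number from compound 1 to compound 4 (0.12 log units; within the scatter), a step in no direction beyond the scatter. Compound 4 is expected to give about 30000 nM in this assay, within the range 8000 nM to 100000 nM.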

Compound 4, concentration for total growth inhibition: 49000 nM
Compound 4: middle estimate off by 1.6-fold (0.21 log units), on the low side, and the stated range covers the measured number.
By their numbers in this assay, from the lowest: compounds 2, 1 and 4 (each within the scatter of the next, the first and the last beyond it).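

In this assay, the exchange on this aromatic carbon, next to the ring nitrogen and ortho to a phenyl group, gives a 1.2-fold higher number from compound 1 to compound 4 (0.09 log units; within the scatter). The earlier compounds shown here offered only a spread of numbers at this position, whereas this pair shows that 3,4-dichlorophenoxy and (4-fluorophenyl)sulfanyl cannot be told apart in this read-out, even with the linking atom and the ring halogens exchanged together. Nothing measured here accounts for this result.

On these data alone, the pair does not separate the linking atom from the ring halogens, so it remains open whether each has its own effect or neither has any. Also open, as far as these compounds go, is whether a piperazine or a longer alkyl chain on this aromatic carbon would shift the number beyond the scatter.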